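The compounds below may be only part of what the source reports. "The series", "measured", "known", "first", "only" and "open" are said of these compounds alone.

Measured compounds in a functional assay for inhibition of sodium/hydrogen exchanger (Oryctolagus cuniculus); on this read-out higher numbers stand for weaker inhibition and lower numbers for stronger inhibition:

Compound 1, `CCC(C)c1cc(C)c(C(=O)N=C(N)N)cc1S(C)(=O)=O`: 8 nM
Compound 2, `Cc1cc(O)c(S(C)(=O)=O)cc1C(=O)N=C(N)N`: 220 nM
Compound 3, `Cc1cn(-c2cc(C)c(C(=O)N=C(N)N)cc2S(C)(=O)=O)cn1`: 28 nM

Compound 3 stands second highest of the three numbers, with compound 1 as its nearest neighbour and compound 2 furthest away. All three share one core and differ only in the group on a single aromatic carbon. The step of a 28-fold higher number from compound 1 to compound 2 (1.44 log units; beyond the scatter) is large, whereas a 3.5-fold higher number from compound 1 to compound 3 (0.54 log units; beyond the scatter) is modest and a 7.9-fold lower number from compound 2 to compound 3 (0.90 log units; beyond the scatter) is also modest, so the three groups at this position span a wide range of outcomes.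

Compound 4, `Cc1cc(Oc2cncc(Cl)c2)c(S(C)(=O)=O)cc1C(=O)N=C(N)N`, has not yet been measured. It differs from compound 3 in one place:

(5-chloropyridin-3-yl)oxy in place of 4-methyl-1H-imidazol-1-yl on an aromatic carbon

Among the measured compounds shown here, the steps that bear on this change are the two that end at compound 3: a hydroxy group here gave a much higher number than the 4-methyl-1H-imidazol-1-yl, while sec-butyl gave a modestly lower one. The entering group is, like the one that leaves, an aromatic ring bearing acceptors and no donor, so a step of at most modest size is expected, with no strong lean in either direction, tending if anything slightly lower, that is a 1.4-fold lower number from compound 3 to compound 4 (0.15 log units; within the scatter). Compound 4 is therefore estimated at 20 nM in this assay, with a range from 5 nM to 80 nM.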

Compound 4, half-maximal inhibitory concentration: 14 nM
For compound 4 the middle estimate is 1.4-fold (0.15 log units) above the measured one, and the stated range covers the measured number.
By their numbers in this assay, from the lowest: compounds 1, 4 and 3 (each within the scatter of the next, the first and the last beyond it); then compound 2.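

In this assay, replacing the 4-methyl-1H-imidazol-1-yl with (5-chloropyridin-3-yl)oxy (a 2.0-fold lower number from compound 3 to compound 4 (0.30 log units; within the scatter)) stays within the scatter, as does the step from sec-butyl (a 1.8-fold higher number from compound 1 to compound 4 (0.24 log units; within the scatter)), so compound 4 cannot be told apart from either compound 1 or compound 3, even though those two lie beyond the scatter of each other. Putting 5-chloropyridin-3-yl on the oxygen of the hydroxy group (a 16-fold lower number from compound 2 to compound 4 (1.20 log units; beyond the scatter)) is a large step, which shows that this oxygen can carry an aromatic ring and leaves compound 2 the weakest of the four. No other data accompany these numbers to explain the differences.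

The compounds shown leave open what the chlorine, the ring nitrogen and the linking oxygen of the (5-chloropyridin-3-yl)oxy group each contribute, a question that a plain phenoxy group, an unsubstituted pyridin-3-yloxy group or a directly attached 5-chloropyridin-3-yl group could address. As far as these compounds go, it is also open how a methoxy group, an amine or a carboxylic acid on this aromatic carbon would read in this assay.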